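Methylation of the Hydroxymethyl Arm in a Hydroxamate Series

The compounds below may be only part of what the source reports. "The series", "measured", "known", "first", "only" and "open" are said of these compounds alone.

Compound 1 `CN(O)C(=O)c1cc2c(CN3CCC(O)C3)cn(Cc3ccc(F)cc3)c2cn1` gives > 100000 nM in an ADME assay on CEM-SS cells (Homo sapiens) for cytotoxicity, read by XTT assay (on this read-out lower numbers stand for higher toxicity in this test and higher numbers for lower toxicity in this test), a limit of the assay.
Compound 2 `CN1CCN(Cc2cn(Cc3ccc(F)cc3)c3cnc(C(=O)N(C)O)cc23)CC1` gives > 224000 nM in this assay, a limit of the assay.
Compound 3 `CN(O)C(=O)c1cc2c(CO)cn(Cc3ccc(F)cc3)c2cn1` gives > 266000 nM in this assay, a limit of the assay.

Compound 3 thus stands only at a limit, and the two other values shown are limits as well, so none of the three compounds can be ordered against another. The measured steps confirm this: a step that the two limits leave unreadable from compound 1 to compound 2, a step that the two limits leave unreadable from compound 1 to compound 3 and a step that the two limits leave unreadable from compound 2 to compound 3 are all unreadable between two limits, so none of them bears a readable size on the step to compound 4 `COCc1cn(Cc2ccc(F)cc2)c2cnc(C(=O)N(C)O)cc12`. The change from compound 3 to compound 4 is methyl in place of hydrogen on an oxygen on a saturated carbon. With every neighbouring step unreadable in this assay, no direction or size can be taken from the data, and the expectation is that compound 4 remains at a limit as well, the estimated step being an at least 1.0-fold lower number from compound 3 to compound 4 (0.02 log units; that floor lies within the scatter). Compound 4 is therefore expected to give about 250000 nM, within a range from 80000 nM to 600000 nM.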

Compound 4, half-maximal cytotoxic concentration: 266000 nM
Estimate against measurement, compound 4: 1.1-fold (0.03 log units) below, within the range that was stated.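

In this assay, among the compounds shown here, compound 4 gives 266000 nM, the only one of the four values shown that is a number and not a limit. Compound 3 gives > 266000 nM, which is a limit of the assay. Methyl in place of hydrogen on this oxygen therefore gives a number no higher from compound 3 to compound 4 (the limit leaves the size open), so this change shows a direction that no earlier pair showed, while the steps to compound 4 from compound 1 and from compound 2 cannot be read.

The compounds shown leave open how large the step from the hydroxy to the methoxy group really is. They also leave open how this read-out would respond to a longer chain on the oxygen, such as ethoxy, or to a primary amine or a carboxylic acid on the same saturated carbon.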